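Replacing the Cyclohexyl Amide with a Triol

This account rests on a few compounds, and the source may have more. Where it says the series, first, only, none or still open, it means among the compounds named here.

The starting point is compound 1, `COc1cccc2cc(C(=O)NC3CCCCC3)c(=N)oc12`. In an assay on HeLa cells for displacement of a labelled ligand from adenosine receptor A3 (Homo sapiens), read by scintillation counting, with a stated time of 180 min, tested at 10 uM (a higher number here means more inhibition at the concentration tested (going by the name of the read-out), a lower number less inhibition), compound 1 gives 16%. Among the three compounds measured, that places compound 1 second of three: compound 2, `COc1cccc2c1OC(C)(O)C(C(C)=O)=C2`, gives 30% in this assay, a number that lies beyond the scatter above compound 1, while compound 3, `N=c1oc2ccc(Br)cc2cc1C(=O)NC1CCCC1`, gives 0% in this assay, a number that lies beyond the scatter below compound 1.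

The unmeasured compound 4, `COc1cccc2cc(C(=O)NC(CO)(CO)CO)c(=N)oc12`, keeps the core of compound 1 and changes only the substituent on the amide nitrogen: 2-hydroxy-1,1-bis(hydroxymethyl)ethyl in place of cyclohexyl on an amide-type nitrogen. Among the compounds with values here, no measured pair in this set alters the group on the amide nitrogen, so the size of such a step cannot be read from these data. With nothing to the contrary, the change is expected to lower the read-out by a modest amount, close to the edge of the usual scatter. For compound 4 the expected step is a number 8 percentage points lower from compound 1 to compound 4 (within the scatter). Compound 4 is therefore estimated at 8% in this assay, with a range from 0% to 24%.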

Compound 4, a percentage reported as inhibition, at one concentration (the size of the read-out at that concentration, not a potency): 18%
Compound 4: middle estimate off by 10 percentage points, on the low side; measured number inside the range.
By their numbers in this assay, from the lowest: compound 3; then compounds 1 and 4 (each within the scatter of the next); then compound 2.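

In this assay, putting 2-hydroxy-1,1-bis(hydroxymethyl)ethyl in place of cyclohexyl on an amide-type nitrogen gives a number 2 percentage points higher from compound 1 to compound 4 (within the scatter), the first step read at this position. The exchange is a large one in what is counted: a six-membered non-aromatic ring of carbon only, with 0 hydrogen-bond donors and 0 hydrogen-bond acceptors, leaves, and a group with no ring, 3 hydrogen-bond donors and 3 hydrogen-bond acceptors enters, yet the two compounds cannot be told apart in this read-out at the single concentration tested. No supporting measurement bears on the reason for this outcome.

From the compounds shown here alone, since each number is the size of the read-out at one concentration and not a potency, it remains open whether compound 1 and compound 4 would also match across a range of concentrations. Going by these compounds, it also remains open whether an amine, a carboxylic acid, a longer carbon chain or a phenyl ring on the amide nitrogen would sit as close to compound 1, and whether the same exchange would give a similar step on the core of compound 3.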